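This account rests on a few compounds, and the source may have more. Where it says the series, first, only, none or still open, it means among the compounds named here.

In an ADME assay on a cell-free system (plasma, Homo sapiens) for metabolic stability, read by LC-MS, with a stated time of 4 h, tested at 100 uM (on this read-out higher numbers stand for a more stable compound and lower numbers for a less stable compound), two compounds sharing one core have been measured so far. Compound 1 `Cn1c(Sc2c(F)cc(C(=O)NO)cc2F)nnc1-c1cccs1` gives 99% and compound 2 `Cn1c(Sc2c(F)cc(C(=O)NO)cc2F)nnc1-c1cccnn1` gives 100%, so compound 2 stands level with compound 1 within the scatter. The account now turns to compound 3 `Cn1c(Sc2c(F)cc(C(=O)NO)cc2F)nnc1-c1ncccc1F`, which keeps the shared core and carries 3-fluoropyridin-2-yl in place of pyridazin-3-yl on an aromatic carbon of the five-membered aromatic ring with 3 nitrogen: 3-fluoropyridin-2-yl in place of pyridazin-3-yl on an aromatic carbon. Among the compounds with values here, only one measured step bears on this change, the exchange of thiophen-2-yl for pyridazin-3-yl at the same place, which amounts to a number 1 percentage points higher from compound 1 to compound 2 (within the scatter). Within the data shown here, this is a single pair, and no measured compound carries 3-fluoropyridin-2-yl, so the evidence is thin. Even so, with that one exchange staying inside the scatter, no step beyond the scatter is expected in this assay. The expected step is a number 2 percentage points lower from compound 2 to compound 3 (within the scatter). Compound 3 is estimated at 98%, with an expected range from 90% to 100%.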

Compound 3, percent of the compound remaining: 97%
Beside the measured number, compound 3's estimate is 1 percentage points above it; low and high end bracket the measured number.
By their numbers in this assay, from the lowest: compounds 3, 1 and 2 (each within the scatter of the next).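

In this assay, this place on an aromatic carbon of a five-membered aromatic ring with 3 nitrogen now has a third group, and 3-fluoropyridin-2-yl gives a number 3 percentage points lower from compound 2 to compound 3 (within the scatter), while the comparison with thiophen-2-yl gives a number 2 percentage points lower from compound 1 to compound 3 (within the scatter). The earlier pair covered only thiophen-2-yl and pyridazin-3-yl, whereas these steps show that a six-membered aromatic ring with 1 hetero atom and a fluorine also stays level with both groups within the scatter, so all three compounds shown remain indistinguishable on this read-out. No measurement at hand accounts for this levelness or connects it to any feature of these groups.

The compounds shown leave open whether the same holds when a group other than an aromatic ring sits at this place, such as an amine, a carboxylic acid or a longer alkyl chain. They also leave open how a change elsewhere on the shared core, such as chlorine in place of fluorine, would read in this assay.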